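This account rests on a few compounds, and the source may have more. Where it says the series, first, only, none or still open, it means among the compounds named here.

For the measured compounds named here, compound 1 `CN1CCN(c2ccc(Nc3nc(-c4cccc(NC(=O)c5ccccc5F)c4)sc3C(=O)O)cc2)CC1` gives 13900 nM in a functional assay on Raji cells (Homo sapiens) for antiproliferative activity, read by CCK-8 assay, with a stated time of 72 h (on this read-out higher numbers stand for weaker inhibition and lower numbers for stronger inhibition), the highest of the two numbers measured so far. Its nearest neighbour is compound 2 `CN1CCN(c2ccc(Nc3nc(-c4cccc(NC(=O)c5ccc(F)c(Cl)c5)c4)sc3C(=O)O)cc2)CC1`, which gives 8740 nM; the step of a 1.6-fold lower number from compound 1 to compound 2 (0.20 log units; within the scatter) is a change on a different carbonyl carbon. Compound 3 `CN1CCN(c2ccc(Nc3nc(-c4cccc(NC(=O)c5ccccc5F)c4)sc3C(N)=O)cc2)CC1` differs from compound 1 by amino in place of hydroxy on a carbonyl carbon. Going by the values given here, no measured step touches that carbonyl carbon, so the expectation rests on compound 1 alone, with a wide range. Compound 3 is expected to give 8000 nM, between 1500 nM and 40000 nM, a step of a 1.7-fold lower number from compound 1 to compound 3 (0.24 log units; within the scatter) that is not expected to exceed the scatter.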

Compound 3, half-maximal inhibitory concentration: 3270 nM
Compound 3: middle estimate off by 2.4-fold (0.39 log units), on the high side; measured number inside the range.
By their numbers in this assay, from the lowest: compound 3; then compounds 2 and 1 (each within the scatter of the next).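

In this assay, for the compounds shown here, carbamoyl in place of carboxy gives a 4.3-fold lower number from compound 1 to compound 3 (0.63 log units; beyond the scatter), the first step beyond the scatter; the change on the other carbonyl carbon, a 1.6-fold lower number from compound 1 to compound 2 (0.20 log units; within the scatter), stays within it. This position therefore responds to the exchange of a single heavy atom, hydroxy to amino, with no computed change in ring, net charge or donor and acceptor counts. No available evidence bears on the cause of this step.

Open, on these data alone, is how a methyl ester or a methylcarbamoyl group would read on this carbonyl carbon. Also open, as far as these compounds go, is whether carbamoyl gives a similar step alongside the 3-chloro-4-fluorophenyl of compound 2.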